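A shorter hydroxyalkyl arm on the shared core

This account rests on a few compounds, and the source may have more. Where it says the series, first, only, none or still open, it means among the compounds named here.

Compound 1 `CC[C@H](Nc1nc(NCc2ccccn2)c2ncn(C(C)C)c2n1)C(O)C(C)(C)C`: > 50000 nM
Compound 2 `CC[C@@H](Nc1nc(NCc2ccccn2)c2ncn(C(C)C)c2n1)C(O)C(C)(C)C`: 29000 nM

In a functional assay on HCT-116 cells (Homo sapiens) for inhibition, read by sulforhodamine B assay, with a stated time of 96 h (a higher number here means a weaker inhibitor of growth, a lower number a stronger inhibitor of growth), compound 1 reports only a limit, > 50000 nM, and not a number. For the measured compounds named here, compound 2 gives 29000 nM in this assay, the sole number among the two. Going by the values given here, the one measured step, an at least 1.7-fold lower number from compound 1 to compound 2 (0.23 log units; that floor lies within the scatter), is a change of drawn configuration only. Compound 3 `CC[C@@H](Nc1nc(NCc2ccccn2)c2ncn(C(C)C)c2n1)C(C)(C)O` carries 1-hydroxy-1-methylethyl in place of 1-hydroxy-2,2-dimethylpropyl on a saturated chain carbon bound to a nitrogen on an aromatic ring and a saturated chain carbon. Among the compounds with values here, no measured step tests such a change, so no direction beyond the scatter is expected. The estimate for compound 3 in this assay is 30000 nM, within 8000 nM to 100000 nM. This estimate amounts to an expected step of a 1.0-fold higher number from compound 2 to compound 3 (0.01 log units; within the scatter).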

Compound 3, concentration for 50% growth inhibition: > 50000 nM
Compound 3 gave a limit, no number (the forecaster's own chance of this, stated with the estimate: 40%); middle value at least 1.6-fold (0.22 log units) from the limit.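

With 1-hydroxy-1-methylethyl in place of 1-hydroxy-2,2-dimethylpropyl on this saturated chain carbon, this assay shows an at least 1.7-fold higher number from compound 2 to compound 3 (0.23 log units; that floor lies within the scatter), so the shorter arm gave no lower number than compound 2. Compound 3 reports only a limit, > 50000 nM, and not a number. The step from compound 1 to compound 3 cannot be read, because both values are limits: the limit of > 50000 nM in this assay, at which 2 of the 3 values shown sit.

On these data alone, how far compound 3 truly lies from compound 2 remains open. So does whether a longer chain, an amine or a carboxylic acid at this saturated chain carbon would give a lower number than compound 2.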